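This account rests on a few compounds, and the source may have more. Where it says the series, first, only, none or still open, it means among the compounds named here.

Measured so far in an ADME assay on cells (Hepatocyte, Homo sapiens) for metabolic stability, with a stated time of 30 min; a lower number here means that less of the compound is left, a higher number that more of the compound is left:

- compound 1, `O=C(OC1CCC(CN2CCN(c3cc(=O)c4cc(C(F)(F)F)cc([N+](=O)[O-])c4s3)CC2)CC1)c1ccco1`: 1%
- compound 2, `O=C(OC1CCC(CN2CCN(c3cc(=O)c4cc(C(F)(F)F)cc([N+](=O)[O-])c4s3)CC2)CC1)c1cccs1`: 2.2%

Both numbers sit at the low end of the scale. Within the data shown here, compound 2 gives the higher of the two readings, yet the single step available, a number 1.2 percentage points higher from compound 1 to compound 2 (within the scatter), is within the scatter, so the two compounds cannot be told apart on this read-out.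

Compound 3, `COc1ccc(C(=O)OC2CCC(CN3CCN(c4cc(=O)c5cc(C(F)(F)F)cc([N+](=O)[O-])c5s4)CC3)CC2)cc1`, differs from compound 2 only at the carbonyl carbon whose other neighbour is the oxygen next to a carbonyl group: 4-methoxyphenyl in place of thiophen-2-yl on a carbonyl carbon. Among the measured compounds shown here, the only measured step, the one from furan-2-yl to thiophen-2-yl, concerns the same position but exchanges one five-membered aromatic ring for another, and it stayed within the scatter. For the measured compounds named here, no measured pair exchanges such a ring for a six-membered aromatic ring of carbon only carrying a methoxy group, so that part of the change is without precedent here.

On the two readings at hand, compound 3 is expected to remain near the floor of this assay, with a step of a number 0.8 percentage points higher from compound 2 to compound 3 (within the scatter) that is not expected to exceed the scatter. The estimate for compound 3 is 3%, ranging from 0.5% to 12%.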

Compound 3, percent of the compound remaining: 12.2%
For compound 3 the middle estimate is 9.2 percentage points below the measured one; measured number outside the range, above it.
By their numbers in this assay, from the lowest: compounds 1, 2 and 3 (each within the scatter of the next, the first and the last beyond it).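

In this assay this position now gives its first step beyond the scatter: 4-methoxyphenyl in place of furan-2-yl on a carbonyl carbon gives a number 11.2 percentage points higher from compound 1 to compound 3 (beyond the scatter) and is modest in size. The exchange of thiophen-2-yl for 4-methoxyphenyl at the same carbon gives a number 10 percentage points higher from compound 2 to compound 3 (within the scatter) and so does not separate those two compounds on this read-out. The position is therefore not wholly silent in this assay, with a six-membered aromatic ring of carbon only carrying a methoxy group resolved from the furan-2-yl compound alone, and nothing at hand bears on why the readings differ.

As far as these compounds go, it remains open whether the step belongs to the six-membered aromatic ring or to its methoxy group, a question that a plain phenyl on the same carbonyl carbon would address. Also open, from the compounds shown here alone, is how the read-out in this assay would respond to an amide nitrogen in place of the oxygen next to a carbonyl group, with the rest of the structure unchanged.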